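Replacing a chlorobutanamide with an acrylamide on a shared core

The compounds below may be only part of what the source reports. "The series", "measured", "known", "first", "only" and "open" are said of these compounds alone.

Measured compounds: compound 1 `CC(C)(C)c1ccc(NC(=O)NCCCCl)cc1`, compound 2 `CC(C)(C)c1ccc(NC(=O)CCl)cc1` and compound 3 `CC(C)(C)c1ccc(NC(=O)CCCCl)cc1`, all sharing one core and differing only at the carbonyl carbon.

In a functional assay on MCF7 cells (Homo sapiens) for antiproliferative activity, with a stated time of 48 h (a lower number here means a stronger inhibitor, a higher number a weaker inhibitor), compound 1 gives 49000 nM. Compound 2 gives 5400 nM in this assay. For compound 3 this assay reports only a limit, > 100000 nM. Compound 3 therefore stands at the weak end of the measured set, shown by an at least 18-fold higher number from compound 2 to compound 3 (1.26 log units; beyond the scatter) and by an at least 2.0-fold higher number from compound 1 to compound 3 (0.30 log units; that floor lies within the scatter).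

Compound 4 `C=CC(=O)Nc1ccc(C(C)(C)C)cc1` differs from compound 3 by vinyl in place of 3-chloropropyl on a carbonyl carbon. Among the compounds with values here, no measured step places a vinyl there, but the chloromethyl of compound 2 gave the lowest value shown, and the step of an at least 18-fold higher number from compound 2 to compound 3 (1.26 log units; beyond the scatter) marks how much was lost with the longer chain. Compound 4 is expected to move back toward compound 2, a step of an at least 12-fold lower number from compound 3 to compound 4 (1.09 log units; beyond the scatter). The estimate for compound 4 is 8000 nM, within 1500 nM to 40000 nM.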

Compound 4, half-maximal inhibitory concentration: 29000 nM
The estimate for compound 4 lay 3.6-fold (0.56 log units) below the measured number, within the range that was stated.
By their numbers in this assay, from the lowest: compound 2; then compounds 4 and 1 (each within the scatter of the next). At a limit, above all of these: compound 3.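

Compound 4 shows that vinyl on this carbonyl carbon regains ground relative to 3-chloropropyl (an at least 3.4-fold lower number from compound 3 to compound 4 (0.53 log units; beyond the scatter)), though this step is only a floor, since compound 3 stands at a limit: the limit of > 100000 nM in this assay, at which 1 of the 4 values shown sits. Vinyl does not match chloromethyl (a 5.4-fold higher number from compound 2 to compound 4 (0.73 log units; beyond the scatter)), so a group without chlorine is tolerated here, but the best value shown still belongs to compound 2. Vinyl and (3-chloropropyl)amino cannot be told apart in this assay (a 1.7-fold lower number from compound 1 to compound 4 (0.23 log units; within the scatter)). As far as these compounds go, whether an ethyl group would perform like vinyl remains open, so the part played by the double bond is unresolved.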